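The compounds below may be only part of what the source reports. "The series", "measured", "known", "first", "only" and "open" are said of these compounds alone.

Measured so far in a functional assay on the whole organism (strain Wistar) for inhibition, with Rattus norvegicus as the target, read by paw edema, with a stated time of 3 h, at a dose of 10 mg/kg by the intraperitoneal route; a lower number here means less inhibition, a higher number more inhibition at the dose given (going by the name of the read-out):
compound 1 `O=C(N/N=C/c1cccc(O)c1)c1cccnc1Nc1cccc(C(F)(F)F)c1` gives 49%
compound 2 `COc1ccc(/C=N/NC(=O)c2cccnc2Nc2cccc(C(F)(F)F)c2)c(OC)c1` gives 24.1%

For the measured compounds named here, compound 2 stands lowest of the two numbers in this assay; its only neighbour is compound 1, and the single measured step, a number 24.9 percentage points lower from compound 1 to compound 2 (beyond the scatter), is the only guide to what this position does. Compound 3 `COc1ccc(/C=N/NC(=O)c2cccnc2Nc2cccc(C(F)(F)F)c2)cc1OC` differs from compound 2 by 3,4-dimethoxyphenyl in place of 2,4-dimethoxyphenyl on a carbon with a double bond to nitrogen. Going by the values given here, no measured step goes from 2,4-dimethoxyphenyl to 3,4-dimethoxyphenyl; the step of a number 24.9 percentage points lower from compound 1 to compound 2 (beyond the scatter) concerns a different exchange at the same place and shows only that a change there can move the read-out beyond the scatter, without telling the direction for this one. The expected step in this assay is therefore a number 5.9 percentage points higher from compound 2 to compound 3 (within the scatter), within the scatter, carried with a wide range. Compound 3 is estimated at 30% in this assay, between 10% and 52%.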

Compound 3, a percentage reported as inhibition, in the whole organism at one dose (the size of the read-out at that dose, not a potency): 44%
Compound 3: middle estimate off by 14 percentage points, on the low side, within the range that was stated.
By their numbers in this assay, from the lowest: compound 2; then compounds 3 and 1 (each within the scatter of the next).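

In this assay the step is a number 19.9 percentage points higher from compound 2 to compound 3 (beyond the scatter) and the two compounds hold the same atoms, so at this place the arrangement of the two methoxy groups on the phenyl ring matters, not merely their presence. The step of a number 5 percentage points lower from compound 1 to compound 3 (within the scatter) does not separate 3,4-dimethoxyphenyl from 3-hydroxyphenyl, so the low number of compound 2 does not extend to every dimethoxyphenyl group in place of 3-hydroxyphenyl. Nothing available gives a cause for either step.

The compounds shown leave open whether a phenyl ring with a single methoxy group would stay level with compound 1 and compound 3 or fall toward compound 2. They also leave open how a phenyl ring carrying an amine or a carboxylic acid would read at this place.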